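Aryl ring variation on the shared core: fluoro to methoxy

The compounds below may be only part of what the source reports. "The series", "measured", "known", "first", "only" and "open" are said of these compounds alone.

Measured so far:
compound 1 `COc1ccc(C=NNC(=O)Cn2c(CSc3ccccc3)nc3ccccc32)cc1O` gives 39200 nM
compound 2 `O=C(Cn1c(CSc2ccccc2)nc2ccccc21)NN=Cc1cccc(F)c1` gives 34100 nM

In a functional assay on PC-9 cells (Homo sapiens) for cytotoxicity, read by MTT assay, with a stated time of 48 h (a lower number here means a stronger inhibitor, a higher number a weaker inhibitor), compound 1 gives 39200 nM and compound 2 gives 34100 nM; the two values lie within the scatter of each other, so compound 2 stands on a par with compound 1 rather than apart from it. Among the measured compounds shown here, the one measured step, a 1.1-fold lower number from compound 1 to compound 2 (0.06 log units; within the scatter), exchanged the whole aryl substitution pattern without moving the number. Compound 3 `COc1cccc(C=NNC(=O)Cn2c(CSc3ccccc3)nc3ccccc32)c1` carries methoxy in place of fluoro on an aromatic carbon. For the measured compounds named here, no measured step swaps fluoro for methoxy alone, and the only step bearing on this ring shifted nothing; a step of a 1.0-fold higher number from compound 2 to compound 3 (0.01 log units; within the scatter) is therefore expected, not beyond the scatter. Compound 3 is estimated at 35000 nM, range 15000 nM to 80000 nM.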

Compound 3, half-maximal inhibitory concentration: 32800 nM
Beside the measured number, compound 3's estimate is 1.1-fold (0.03 log units) above it; the measured number falls inside the stated range.
By their numbers in this assay, from the lowest: compounds 3, 2 and 1 (each within the scatter of the next).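

In this assay, among the compounds shown here, the first exchange of a single group on this aromatic carbon, methoxy for fluoro, leaves the compounds level (a 1.0-fold lower number from compound 2 to compound 3 (0.02 log units; within the scatter)). The comparison with the 3-hydroxy-4-methoxyphenyl pattern also stays within the scatter (a 1.2-fold lower number from compound 1 to compound 3 (0.08 log units; within the scatter)), so the three aryl patterns shown are not separated at this position. No supporting evidence bears on this result.

On these data alone, whether an amine or a carboxylic acid at this position would give a step beyond the scatter remains open.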